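Changing the aryl group on an aromatic nitrogen

A few compounds are considered here, and "the series" means these few. Any claim that something is new, unique, unknown or untested is made for them only; others in the source may bear on it.

Measured so far in a functional assay on PC-12 cells (Rattus norvegicus) for cytotoxicity, read by MTT assay, with stated times of 2 h and 24 h, tested at 5 uM; a higher number here means a stronger effect of the compound at the concentration tested, a lower number a weaker effect:
Compound 1, `Oc1cc(C(F)(F)F)ccc1-c1nc(-c2ccccc2O)n(-c2ccc(C(F)(F)F)cc2)n1`, gives 90.5%.
Compound 2, `Oc1cc(C(F)(F)F)ccc1-c1nc(-c2ccccc2O)n(-c2cccc(F)c2)n1`, gives 87.7%.

Compound 2 and compound 1 stand within the scatter of each other, as the step of a number 2.8 percentage points lower from compound 1 to compound 2 (within the scatter) shows. Compound 3 is `Oc1cc(C(F)(F)F)ccc1-c1nc(-c2ccccc2O)n(-c2ccc(Cl)cc2Cl)n1`. It differs from compound 2 as follows: 2,4-dichlorophenyl in place of 3-fluorophenyl on an aromatic nitrogen. Going by the values given here, the single measured step bears on this change only loosely, as it too exchanged the group on that aromatic nitrogen and stayed within the scatter. No shift beyond the scatter is therefore expected in this assay, and the step of a number 0.3 percentage points higher from compound 2 to compound 3 (within the scatter) is expected to be small. Compound 3 is estimated at 88%, within 76% to 96%.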

Compound 3, a percentage reported as activity, at one concentration (the size of the read-out at that concentration, not a potency): 86.7%
Compound 3: middle estimate off by 1.3 percentage points, on the high side; measured number inside the range.
By their numbers in this assay, from the lowest: compounds 3, 2 and 1 (each within the scatter of the next).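

Placing 2,4-dichlorophenyl on this aromatic nitrogen gives a step in this assay of a number 1 percentage points lower from compound 2 to compound 3 (within the scatter), and a number 3.8 percentage points lower from compound 1 to compound 3 (within the scatter) for the comparison with the 4-(trifluoromethyl)phenyl group. All three aryl groups shown, now including one with two chlorine atoms, therefore read alike at this position. Nothing available here explains this likeness. The compounds shown leave open whether an aryl group carrying an amine or a carboxylic acid, or a longer alkyl chain in place of the aryl ring, would move the number beyond the scatter.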